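Replacing Amino With a Heteroaromatic Ring on the Shared Core

The compounds below may be only part of what the source reports. "The series", "measured", "known", "first", "only" and "open" are said of these compounds alone.

Compound 1 `Cc1cc(-c2ccccc2)c(S(C)(=O)=O)cc1C(=O)N=C(N)N` gives 19 nM in a functional assay for inhibition of sodium/hydrogen exchanger (Oryctolagus cuniculus); on this read-out lower numbers stand for stronger inhibition and higher numbers for weaker inhibition.
Compound 2 `Cc1cc(N)c(S(C)(=O)=O)cc1C(=O)N=C(N)N` gives 16 nM in this assay.

In this assay compound 2 stands alongside compound 1: the step of a 1.2-fold lower number from compound 1 to compound 2 (0.07 log units; within the scatter) lies within the scatter, so the two numbers cannot be told apart. Compound 3 `Cc1cc(-n2ccc(=O)cc2)c(S(C)(=O)=O)cc1C(=O)N=C(N)N` has not yet been measured; it differs from compound 2 in one place: a group of 7 heavy atoms (5 carbon, 1 nitrogen, 1 oxygen; one six-membered aromatic ring with 1 hetero atom) in place of one nitrogen atom, on an aromatic carbon. For the measured compounds named here, the only measured step that touches this position is a 1.2-fold lower number from compound 1 to compound 2 (0.07 log units; within the scatter), where phenyl and amino gave numbers within the scatter of each other, which suggests this position tolerates groups of quite different size. The ring entering in compound 3 is again a six-membered aromatic ring, now with one hetero atom. The expected step is therefore a 1.3-fold higher number from compound 2 to compound 3 (0.10 log units; within the scatter), with nothing beyond the scatter. Compound 3 is estimated at 20 nM in this assay, with a range from 7 nM to 60 nM.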

Compound 3, half-maximal inhibitory concentration: 75 nM
Beside the measured number, compound 3's estimate is 3.8-fold (0.57 log units) below it; the whole stated range lies below it.
By their numbers in this assay, from the lowest: compounds 2 and 1 (each within the scatter of the next); then compound 3.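

In this assay the position ortho to a methylsulfonyl group proves less open than amino and phenyl alone suggested: the ring entering in compound 3 gives a 4.7-fold higher number from compound 2 to compound 3 (0.67 log units; beyond the scatter) against amino and a 3.9-fold higher number from compound 1 to compound 3 (0.60 log units; beyond the scatter) against phenyl, which is also a six-membered aromatic ring. Size alone therefore does not track the number here, as phenyl and amino stand within the scatter of each other, while two six-membered aromatic rings on the same aromatic carbon do not. Nothing available accounts for the difference between these two rings.

On these data alone, whether the higher number goes with the ring nitrogen or with the carbonyl remains open. Also open, as far as these compounds go, is how a saturated ring such as piperidine, or a small substituted amine such as dimethylamino, would read on this aromatic carbon.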